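The source may hold more compounds than are shown below. What is called first, only, known or untested is meant among the compounds shown, and "the series" means these compounds.

Series notes, read-out a functional assay for inhibition of sodium/hydrogen exchanger (Oryctolagus cuniculus); on this read-out lower numbers stand for stronger inhibition and higher numbers for weaker inhibition:
- compound 1, `Cc1cc(-c2ccc(Cl)cc2Cl)c(S(C)(=O)=O)cc1C(=O)N=C(N)N`: 42 nM
- compound 2, `Cc1cc(OC2CCCC2)c(S(C)(=O)=O)cc1C(=O)N=C(N)N`: 27 nM
- compound 3, `Cc1cc(-n2cccn2)c(S(C)(=O)=O)cc1C(=O)N=C(N)N`: 25 nM

On the numbers shown compound 3 sits at the low end of the three, yet neither step to it separates from the scatter: a 1.7-fold lower number from compound 1 to compound 3 (0.23 log units; within the scatter) and a 1.1-fold lower number from compound 2 to compound 3 (0.03 log units; within the scatter). The remaining step, a 1.6-fold lower number from compound 1 to compound 2 (0.19 log units; within the scatter), is likewise within the scatter. The three groups tried on this aromatic carbon therefore give numbers that cannot be told apart.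

Compound 4, `Cc1cc(-n2ccc(=O)cc2)c(S(C)(=O)=O)cc1C(=O)N=C(N)N`, is not yet measured. The change from compound 3 is a group of 7 heavy atoms (5 carbon, 1 nitrogen, 1 oxygen; one six-membered aromatic ring with 1 hetero atom) in place of a group of 5 heavy atoms (3 carbon, 2 nitrogen; one five-membered aromatic ring with 2 hetero atoms), on an aromatic carbon. The two steps that bear on this position, a 1.7-fold lower number from compound 1 to compound 3 (0.23 log units; within the scatter) and a 1.1-fold lower number from compound 2 to compound 3 (0.03 log units; within the scatter), each exchanged one group for another on the same aromatic carbon and stayed within the scatter. No step beyond the scatter is therefore expected in this assay for compound 4, whose expected step is a 1.2-fold higher number from compound 3 to compound 4 (0.08 log units; within the scatter). Compound 4 is estimated at 30 nM, with a range of 12 nM to 80 nM.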

Compound 4, half-maximal inhibitory concentration: 75 nM
Compound 4: middle estimate off by 2.5-fold (0.40 log units), on the low side; measured number inside the range.
By their numbers in this assay, from the lowest: compounds 3, 2, 1 and 4 (each within the scatter of the next, the first and the last beyond it).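

In this assay this aromatic carbon now gives steps beyond the scatter: a 3.0-fold higher number from compound 3 to compound 4 (0.48 log units; beyond the scatter) and a 2.8-fold higher number from compound 2 to compound 4 (0.44 log units; beyond the scatter) are both modest, whereas a 1.8-fold higher number from compound 1 to compound 4 (0.25 log units; within the scatter) stays within it. The group entering in compound 4 thus separates from 1H-pyrazol-1-yl and cyclopentyloxy but not from 2,4-dichlorophenyl, so the position is not indifferent to every exchange. Nothing at hand explains this difference.

Open is whether the carbonyl of the entering group or its six-membered ring goes with the higher number in compound 4, since no pair shown changes one without the other. Also open, as far as these compounds go, is how a dimethylamino group or a carboxylic acid on this aromatic carbon would read in this assay on the same core.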